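The compounds below may be only part of what the source reports. "The series", "measured", "known", "first", "only" and "open" are said of these compounds alone.

Measured compounds:
- compound 1 `COc1cc(/C=C/C(=O)c2cccc(-n3cc(-c4ccccc4)[nH]c3=O)c2)ccc1O`: 2190 nM
- compound 2 `O=C(/C=C/c1cccc(O)c1)c1cccc(-n2cc(-c3ccc(Cl)cc3)[nH]c2=O)c1`: 1720 nM
- compound 3 `COc1ccc(-c2cn(-c3cccc(C(=O)/C=C/c4ccc(O)c(OC)c4)c3)c(=O)[nH]2)cc1`: 4990 nM

All three were run in a functional assay on CAKI-1 cells (Homo sapiens) for inhibition; on this read-out lower numbers stand for stronger inhibition of growth and higher numbers for weaker inhibition of growth. Compound 3 holds the highest number of the three; compound 1 is the nearest to it, compound 2 the furthest, and both gaps are beyond the scatter.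

Compound 4 `COc1cc(/C=C/C(=O)c2cccc(-n3cc(-c4ccc(Cl)cc4)[nH]c3=O)c2)ccc1O` differs from compound 3 in one place: chloro in place of methoxy on an aromatic carbon. Within the data shown here, the one measured step that bears on this position is a 2.3-fold higher number from compound 1 to compound 3 (0.36 log units; beyond the scatter), which shows that putting a methoxy there raises the number. Compound 4 instead carries a chloro there. Among the measured compounds shown here, no measured pair isolates a chloro against a methoxy or against hydrogen at this position; compound 2 does carry a chloro on that ring, but it also differs from compound 4 elsewhere, so only its value can be noted. Taken together, the expectation is that compound 4 returns toward the range of compound 1 and compound 2 rather than staying near compound 3, giving an expected step of a 2.5-fold lower number from compound 3 to compound 4 (0.40 log units; beyond the scatter). The estimate for compound 4 is 2000 nM, with a range from 900 nM to 4500 nM.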

Compound 4, concentration for 50% growth inhibition: 2640 nM
The estimate for compound 4 lay 1.3-fold (0.12 log units) below the measured number, and the stated range covers the measured number.
By their numbers in this assay, from the lowest: compounds 2, 1, 4 and 3 (each within the scatter of the next, the first and the last beyond it).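

In this assay chloro on this aromatic carbon does not separate from hydrogen, with a 1.2-fold higher number from compound 1 to compound 4 (0.08 log units; within the scatter) against a 2.3-fold higher number from compound 1 to compound 3 (0.36 log units; beyond the scatter) for methoxy in place of hydrogen, so the rise seen with methoxy is not shared by chloro. Chloro in place of methoxy gives a 1.9-fold lower number from compound 3 to compound 4 (0.28 log units; within the scatter) and thus falls short of a readable gain, which places compound 4 in an unresolved middle position instead of clearly back with compound 1. The change on the other side of the molecule, with a 1.5-fold higher number from compound 2 to compound 4 (0.19 log units; within the scatter) in a chloro-bearing pair, also stays unresolved, so the 4-hydroxy-3-methoxyphenyl and 3-hydroxyphenyl groups cannot be told apart here.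

Still open, going by these compounds, is whether an amine or a carboxylic acid at this place would move the number beyond the scatter. Nothing at hand accounts for the methoxy step.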